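The source may report more compounds than this note shows. Statements on the series, on what has been measured and on what is new or still open speak of the compounds shown alone.

Measured compounds in an in vitro assay on cells for binding affinity to myelin-associated glycoprotein (Mus musculus), read by surface plasmon resonance; a lower number here means tighter binding, a higher number weaker binding:
- compound 1 `CC(=O)N[C@H]1[C@H]([C@@H](O)[C@H](O)CNC(=O)c2ccc(Cl)cc2)O[C@@](OCc2ccccc2)(C(=O)O)C[C@@H]1O`: 17000 nM
- compound 2 `CC(=O)N[C@H]1[C@H]([C@@H](O)[C@H](O)CNC(=O)c2ccc(Cl)cc2)O[C@@](OCc2ccc(F)cc2)(C(=O)O)C[C@@H]1O`: 13000 nM
- compound 3 `CC(=O)N[C@H]1[C@H]([C@@H](O)[C@H](O)CNC(=O)c2ccc(Cl)cc2)O[C@@](OCc2ccc3ccccc3c2)(C(=O)O)C[C@@H]1O`: 11600 nM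

Compound 3 carries the lowest number of the three, but its separation from the rest is small: the step of a 1.5-fold lower number from compound 1 to compound 3 (0.17 log units; within the scatter) and the step of a 1.1-fold lower number from compound 2 to compound 3 (0.05 log units; within the scatter) both fall inside the usual scatter, as does a 1.3-fold lower number from compound 1 to compound 2 (0.12 log units; within the scatter). On these numbers the three benzylic variants at the glycosidic oxygen are indistinguishable.

Compound 4 `CC(=O)N[C@H]1[C@H]([C@@H](O)[C@H](O)CNC(=O)c2ccc(Cl)cc2)O[C@@](OCc2cccc(Cl)c2Cl)(C(=O)O)C[C@@H]1O` differs from compound 3 in one place: 2,3-dichlorophenyl in place of naphthalen-2-yl on a saturated chain carbon bound to an oxygen on a saturated carbon. The change exchanges one flat aromatic group for another, and the earlier changes of this kind across the series (fluorophenyl in place of phenyl, naphthalenyl in place of phenyl or fluorophenyl) moved this assay only within the scatter. Among the measured compounds shown here, no measured step indicates that the group at this position drives the dissociation constant.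

Accordingly, compound 4 is expected to sit close to compound 3, with the estimated step of a 1.0-fold higher number from compound 3 to compound 4 (0.01 log units; within the scatter) not exceeding the scatter. The estimate for compound 4 in this assay is 12000 nM, with a range of 5000 nM to 30000 nM.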

Compound 4, dissociation constant in the myelin-associated glycoprotein assay: 4300 nM
Estimate against measurement, compound 4: 2.8-fold (0.45 log units) above; the whole stated range lies above it.
By their numbers in the myelin-associated glycoprotein assay, from the lowest: compound 4; then compounds 3, 2 and 1 (each within the scatter of the next).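

In the myelin-associated glycoprotein assay, the group on the saturated chain carbon bound to an oxygen on a saturated carbon now moves the read-out: with 2,3-dichlorophenyl, compound 4 gives 4300 nM, which is a 2.7-fold lower number from compound 3 to compound 4 (0.43 log units; beyond the scatter), a 3.0-fold lower number from compound 2 to compound 4 (0.48 log units; beyond the scatter) and a 4.0-fold lower number from compound 1 to compound 4 (0.60 log units; beyond the scatter), while the exchanges among phenyl, 4-fluorophenyl and naphthalen-2-yl stayed within the scatter. So the position responds to the group placed there, and here the single ring with fewer heavy atoms outdoes the two-ring naphthalen-2-yl. In a physicochemical assay for lipophilicity, using the shake flask method, measured as octanol-water partition, at pH 7.4 (on this read-out lower numbers stand for lower lipophilicity and higher numbers for higher lipophilicity), compound 3 gives 0.58 and compound 4 gives 0.53, which is a number 0.05 log units lower from compound 3 to compound 4 (within the scatter), and nothing measured here accounts for the step in binding.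

The compounds shown do not say whether the two chlorines or the substitution pattern carries the step; a 3-chlorophenyl or a 2,3-dimethylphenyl group at this place would separate these. Also open, as far as these compounds go, is whether the step survives with another group in place of the 4-chlorobenzoyl amide.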